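A few compounds are considered here, and "the series" means these few. Any claim that something is new, unique, unknown or untested is made for them only; others in the source may bear on it.

Measured compounds:
Compound 1, `CCC(C)C(NC(=O)n1nnc2ccccc21)C(=O)NC1CCCCC1`, gives 76 ug/mL.
Compound 2, `O=C1NC(c2ccccc2)C(=O)N1C1CCCC1`, gives 27.4 ug/mL.
Compound 3, `CC(C)C1NC(=O)N(C2CCCCC2)C1=O`, gives > 50 ug/mL.

All three values come from a functional assay on HEL cells (Homo sapiens) for cytotoxicity; on this read-out lower numbers stand for higher toxicity in this test and higher numbers for lower toxicity in this test. Compound 1 and compound 2 each return a number. For compound 3 the result is only a limit, > 50 ug/mL, which is to say the assay reached its cap without a half-maximal cytotoxic concentration being found; this is the limit of > 50 ug/mL in this assay, at which 1 of the 3 values shown sits. On these data alone, compound 3 therefore stands at the gentle end of the three, although how far past the cap it lies is unknown.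

Compound 4, `CCC(C)C1NC(=O)N(C2CCCCC2)C1=O`, has not yet been measured in this assay. It differs from compound 3 in one place: methyl in place of hydrogen on a saturated chain carbon, two bonds along the chain from a saturated ring carbon. Going by the values given here, since compound 3 gave only a limit, no measured step in this assay guides the size of the change. Given the small addition, the step from compound 3 to compound 4 is expected to be a step that the limit leaves unreadable from compound 3 to compound 4, that is, no change beyond the scatter. Compound 4 is accordingly estimated at 60 ug/mL, within a range from 30 ug/mL to 120 ug/mL, with a fair chance that this assay again reports only a limit.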

Compound 4, half-maximal cytotoxic concentration: > 50 ug/mL
Compound 4 gave a limit, no number (the forecaster's own chance of this, stated with the estimate: 65%); the middle value lies beyond the limit too.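

In this assay compound 3 and compound 4 each return only a limit, and no step can be read from one to the other. The compounds shown leave open how far past that limit either lies, and whether the added methyl shifts the half-maximal cytotoxic concentration at all.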